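Working notes on the series: from compound 1 to compound 4

The compounds below may be only part of what the source reports. "The series", "measured", "known", "first", "only" and "open" are said of these compounds alone.

The series is followed in an ADME assay on MT4 cells (Homo sapiens) for cytotoxicity, read by MTT assay; a lower number here means that less compound is tolerated, a higher number that more compound is tolerated. Compound 1, `O=C1NC(=S)S/C1=C\c1ccc(-c2ccc(C(=O)O)c(O)c2)o1`, gives only a limit in this assay, > 72000 nM, and not a number. That limit is where compound 1 stands on the numbers shown, as the limit of > 72000 nM in this assay, at which 1 of the 3 values shown sits, records. Compound 2, `COc1cc(-c2ccc(/C=C3\SC(=S)NC3=O)o2)c(Cl)cc1C(=O)O`, gives 143000 nM in this assay. Compound 3, `O=C1NC(=S)S/C1=C\c1ccc(-c2cc(C(=O)O)cc(O)c2O)o1`, gives 131000 nM in this assay. Going by the values given here, the values of compound 2 and compound 3 lie close together, and no step between any two measured compounds is counted here, so no measured step sets the scale for the change in hand.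

Compound 4, `COc1cc(-c2ccc(C(=O)O)c(O)c2)oc1/C=C1\SC(=S)NC1=O`, is not yet measured. It differs from compound 1 by methoxy in place of hydrogen on an aromatic carbon. Among the compounds with values here, with no measured step to lean on, the expectation rests on the three values shown, all of which sit at high concentration in this assay. The step from compound 1 to compound 4 is expected to be a step that the limit leaves unreadable from compound 1 to compound 4, that is, nothing beyond the scatter in either direction. Compound 4 is therefore estimated at 110000 nM, within 60000 nM to 200000 nM, with a real chance that this assay again returns only a limit rather than a number.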

Compound 4, half-maximal cytotoxic concentration: > 125000 nM
Compound 4 was reported as a limit; the forecaster's own chance of this, stated with the estimate: 45%; middle value at least 1.1-fold (0.05 log units) from the limit.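

Compound 4 returns only a limit in this assay (> 125000 nM). Compound 1 is also only a limit (> 72000 nM), and no step can be read between the two compounds. The compounds shown leave open what methoxy in place of hydrogen on an aromatic carbon does to the tolerated concentration, in size or in direction.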